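Thiourea series: methyl to methoxy on the aryl

The compounds below may be only part of what the source reports. "The series", "measured", "known", "first", "only" and "open" are said of these compounds alone.

Measured so far in a functional assay on HL-60 cells (Homo sapiens) for antiproliferative activity, with a stated time of 24 h; on this read-out lower numbers stand for stronger inhibition and higher numbers for weaker inhibition:
compound 1 `NC(=O)c1c(NC(=O)c2ccccc2Cl)sc2c1CCN(Cc1ccccc1Cl)C2`: 2900 nM
compound 2 `Cc1ccccc1NC(=S)N1CCc2c(sc(NC(=O)c3ccccc3Cl)c2C(N)=O)C1`: 22600 nM

Compound 2 stands at the highest number of the two measured in this assay; the nearest neighbour is compound 1, and the step of a 7.8-fold higher number from compound 1 to compound 2 (0.89 log units; beyond the scatter) separates them. That step is the only one measured, and it concerns the group on the amine nitrogen in the ring of the shared core.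

Compound 3 `COc1ccccc1NC(=S)N1CCc2c(sc(NC(=O)c3ccccc3Cl)c2C(N)=O)C1` is not yet measured. It differs from compound 2 by methoxy in place of methyl on an aromatic carbon. For the measured compounds named here, no measured pair touches this position: the step of a 7.8-fold higher number from compound 1 to compound 2 (0.89 log units; beyond the scatter) exchanges the whole substituent on the ring nitrogen and says nothing about a small change on the aromatic ring attached to the thiourea. Methyl and methoxy are close in size, and both compounds keep the thiourea and the rest of the core unchanged.

The expectation is therefore no step beyond the scatter, an estimated step of a 1.1-fold lower number from compound 2 to compound 3 (0.05 log units; within the scatter) in this assay. Compound 3 is estimated at 20000 nM, with a range from 7000 nM to 60000 nM, the weak end of the series.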

Compound 3, half-maximal inhibitory concentration: 40900 nM
Compound 3: the middle estimate sits 2.0-fold (0.31 log units) below what was measured, within the range that was stated.
By their numbers in this assay, from the lowest: compound 1; then compounds 2 and 3 (each within the scatter of the next).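

In this assay, methoxy in place of methyl on an aromatic carbon, ortho to a large group, gives a 1.8-fold higher number from compound 2 to compound 3 (0.26 log units; within the scatter), so this first reading at the position does not separate 2-methoxyphenyl from 2-methylphenyl on the thiourea. Compound 1 remains apart from both thioureas: a 14-fold higher number from compound 1 to compound 3 (1.15 log units; beyond the scatter) stands with a 7.8-fold higher number from compound 1 to compound 2 (0.89 log units; beyond the scatter), and both steps lie beyond the scatter, so the separation from compound 1 holds with either aryl group in place. Nothing available bears on why these numbers fall as they do.

The compounds shown leave open whether a larger change at this aromatic carbon, such as a hydroxyl group, an amine or a longer alkoxy chain, would move the number beyond the scatter. They also leave open whether methyl and methoxy would still read alike elsewhere on that ring, and how a urea with oxygen in place of the thiourea sulfur would compare with compound 2.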